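This account rests on a few compounds, and the source may have more. Where it says the series, first, only, none or still open, it means among the compounds named here.

Measured so far in a functional assay on MDA-MB-231 cells (Homo sapiens) for inhibition, read by resazurin assay, with a stated time of 72 h; a lower number here means a stronger inhibitor, a higher number a weaker inhibitor:

- compound 1 `CC(=O)O[C@@H]1C=C[C@H](O)[C@@H](O)/C1=C/OC(=O)c1ccccc1`: 30 nM
- compound 2 `CC(=O)OC(OC(=O)c1ccccc1)C1=CC=C[C@H](O)[C@H]1OC(C)=O`: 290 nM
- compound 3 `CC(=O)O[C@H]1C=C[C@H](Cl)[C@@](O)(COC(=O)c2ccccc2)[C@@H]1O`: 120 nM

Among these three, compound 3 stands second highest in this assay. Its nearest neighbour is compound 2, whose number is higher, and the gap lies beyond the scatter; its furthest is compound 1, whose number is lower, again beyond the scatter. Compound 3 is thus neither the strongest nor the weakest inhibitor of the set.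

The next compound, compound 4 `CC(=O)O[C@H]1C=C[C@H](Cl)[C@](O)(COC(=O)c2ccccc2)[C@@H]1O`, keeps every atom and bond of compound 3 and changes only the drawn configuration: the two compounds have the same atoms and bonds and differ only in configuration as drawn: 1 of 4 stereo elements differ; a stereocentre at a saturated ring carbon is drawn R in compound 3 and S in compound 4.

Among the measured compounds shown here, no pair of measured compounds differs in one place, and no pair shows what a change of configuration alone does in this assay. The direction of the step is therefore open. Because the value of compound 3 is 120 nM and the set gives no sign that a single inversion shifts the number far, the step is expected to be small, quite possibly within the scatter, in either direction; the expected step is a 1.3-fold higher number from compound 3 to compound 4 (0.10 log units; within the scatter).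

For compound 4 the estimated value in this assay is 150 nM, within a range from 40 nM to 550 nM.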

Compound 4, half-maximal inhibitory concentration: 450 nM
Estimate against measurement, compound 4: 3.0-fold (0.48 log units) below; low and high end bracket the measured number.
By their numbers in this assay, from the lowest: compound 1; then compound 3; then compounds 2 and 4 (each within the scatter of the next).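

Inverting the stereocentre at a saturated ring carbon from R to S gives a 3.8-fold higher number from compound 3 to compound 4 (0.57 log units; beyond the scatter) in this assay, so the drawn configuration at this position registers in the read-out. Among the compounds shown here, this is the first single change that can be read, as no earlier pair differed in one place, and compound 3, drawn R, is the stronger inhibitor of this pair. The step can be assigned to this stereocentre alone, because nothing else separates the two compounds: the fact that compounds 3 and 4 differ only in the configuration as drawn

The compounds shown leave open what inversion does at the other stereo elements, and how compound 1 and compound 2 relate to this pair, since neither differs from it in one place. For the compounds shown here, it also remains open whether the preference for the R form persists with an amine in place of the hydroxyl on this stereocentre, and the single pair offers no mechanism for the step, only its direction and size in this one cell assay.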